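The source may hold more compounds than are shown below. What is called first, only, known or untested is meant among the compounds shown, and "the series" means these compounds.

Measured compounds:
compound 1, `COc1cccc(C(O)CCn2nc3c(Br)c(Br)c(Br)c(Br)c3n2)c1`, in a functional assay on MCF7 cells (Homo sapiens) for antiproliferative activity, read by MTT assay, with a stated time of 48 h, tested at 12.5 uM (on this read-out higher numbers stand for a weaker effect at the one concentration tested and lower numbers for a stronger effect), compound 1 gives 97%
compound 2, `C[C@H](O)CCn1nc2c(Br)c(Br)c(Br)c(Br)c2n1`, in this assay compound 2 gives 100%
compound 3, `OC(CCn1nc2c(Br)c(Br)c(Br)c(Br)c2n1)c1ccc(Br)cc1`, in this assay compound 3 gives 107%

Compound 3 carries the highest of the three numbers, yet neither neighbour is separated from it by more than the scatter: compound 2 sits closest and compound 1 furthest, both within the usual spread. Among the measured compounds shown here, the only step recorded among the measured compounds, a number 10 percentage points higher from compound 1 to compound 3 (within the scatter), swaps one aryl group for another at the carbinol carbon and leaves the read-out essentially unmoved.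

Compound 4, `CC(O)CCn1nc2c(Br)c(Br)c(Br)c(Br)c2n1`, is not yet measured. It differs from compound 3 in one place: methyl in place of 4-bromophenyl on a saturated chain carbon bound to an oxygen on a saturated carbon and a saturated chain carbon. Compound 2 already carries a methyl at this same place and gives a number close to that of compound 3, so the values of those two compounds show no separation beyond the scatter. The aryl swap and the methyl comparison therefore point the same way, and the expected step is a number 7 percentage points lower from compound 3 to compound 4 (within the scatter), no movement beyond the scatter. Compound 4 is estimated at 100%, within a range from 88% to 112%.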

Compound 4, a percentage reported as activity, at one concentration (the size of the read-out at that concentration, not a potency): 79%
Compound 4: middle estimate off by 21 percentage points, on the high side, outside the stated range (below it).
By their numbers in this assay, from the lowest: compound 4; then compounds 1, 2 and 3 (each within the scatter of the next).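

In this assay methyl in place of 4-bromophenyl gives a number 28 percentage points lower from compound 3 to compound 4 (beyond the scatter) and methyl in place of 3-methoxyphenyl gives a number 18 percentage points lower from compound 1 to compound 4 (beyond the scatter) at this position, the first movements here beyond the scatter. Yet methyl alone does not fix the number: compound 2 carries it too, and a number 21 percentage points lower from compound 2 to compound 4 (beyond the scatter) stands between two drawings of the same atoms and bonds. The drop can therefore be laid to the loss of the aryl groups only with care, and one feature alone remains to account for the gap between the two methyl compounds: the fact that one of compounds 2 and 4 is drawn with a defined configuration and the other without, at the place where they differ

The compounds shown leave open what the single opposite configuration of the methyl compound would give, and whether either aryl compound depends on its configuration at this carbon. They also leave open whether ethyl or a longer chain in this place would follow methyl or the aryl groups.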